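This account rests on a few compounds, and the source may have more. Where it says the series, first, only, none or still open, it means among the compounds named here.

Working notes on the series. Three compounds of the shared core carry the same ethylurea and the same tertiary alcohol-bearing pyrimidine, and differ only in the amine attached to the saturated chain carbon bound to the pyridine: compound 1 `CCNC(=O)Nc1nc2cc(-c3cnc(C(C)(C)O)nc3)cc(-c3cc(CN4CC(OC)C4)ccn3)c2s1`, compound 2 `CCNC(=O)Nc1nc2cc(-c3cnc(C(C)(C)O)nc3)cc(-c3cc(CNC4CC4)ccn3)c2s1` and compound 3 `CCNC(=O)Nc1nc2cc(-c3cnc(C(C)(C)O)nc3)cc(-c3cc(CN4CCCC4)ccn3)c2s1`. In an ADME assay on a cell-free system (plasma, Mus musculus) for protein binding, using ultracentrifugation (on this read-out lower numbers stand for a smaller free fraction and higher numbers for a larger free fraction), compound 1 gives 0.11, compound 2 gives 0.056 and compound 3 gives 0.067. Every measured step lies within the scatter: a 2.0-fold lower number from compound 1 to compound 2 (0.29 log units; within the scatter), a 1.6-fold lower number from compound 1 to compound 3 (0.22 log units; within the scatter) and a 1.2-fold higher number from compound 2 to compound 3 (0.08 log units; within the scatter). Compound 3 therefore stands second highest of the three numbers, nearest to compound 2 and furthest from compound 1, with neither gap meaningful.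

The next compound is compound 4 `CCNC(=O)Nc1nc2cc(-c3cnc(C(C)(C)O)nc3)cc(-c3cc(CN4CC[C@@H](O)C4)ccn3)c2s1`, which differs from compound 3 by hydroxy in place of hydrogen on a saturated ring carbon. Going by the values given here, no measured step adds a hydroxy to a ring; the closest comparison is the exchange of the whole amine, where a 1.6-fold lower number from compound 1 to compound 3 (0.22 log units; within the scatter) moved from a ring bearing a methoxy to a bare pyrrolidin-1-yl and stayed within the scatter. Given that, compound 4 is expected to sit close to compound 3 in this assay, with the estimated step of a 1.3-fold higher number from compound 3 to compound 4 (0.13 log units; within the scatter) not exceeding the scatter. The estimate for compound 4 is 0.09, with a range from 0.05 to 0.16.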

Compound 4, unbound fraction: 0.194
For compound 4 the middle estimate is 2.2-fold (0.33 log units) below the measured one; the whole stated range lies below it.
By their numbers in this assay, from the lowest: compounds 2, 3, 1 and 4 (each within the scatter of the next, the first and the last beyond it).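

In this assay, hydroxy in place of hydrogen on a saturated ring carbon, two ring bonds from the ring nitrogen, produces a change beyond the scatter (a 2.9-fold higher number from compound 3 to compound 4 (0.46 log units; beyond the scatter)), whereas every step among the earlier amines stayed within it, so this ring carbon is a place where one added heavy atom can be read in the unbound fraction. The exchange of cyclopropylamino for 3-hydroxypyrrolidin-1-yl also lies beyond the scatter (a 3.5-fold higher number from compound 2 to compound 4 (0.54 log units; beyond the scatter)), but the exchange of 3-methoxyazetidin-1-yl for the same group stays within it (a 1.8-fold higher number from compound 1 to compound 4 (0.25 log units; within the scatter)), so compound 1 and compound 4 cannot be told apart and both ring-oxygenated amines remain in one range. Nothing available here bears on why the added hydroxy has this effect.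

Whether the step belongs to the hydroxy alone stays open, since the compounds shown do not include 3-methoxypyrrolidin-1-yl, 3-aminopyrrolidin-1-yl or 3-fluoropyrrolidin-1-yl at this position. From the compounds shown here alone, the opposite configuration at the hydroxy-bearing ring carbon is also open, as is the same hydroxy on a ring of another size.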